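A few compounds are considered here, and "the series" means these few. Any claim that something is new, unique, unknown or untested is made for them only; others in the source may bear on it.

The compounds measured so far:

Compound 1 `COc1cc[nH]c1/C=C1/C(=O)Nc2ccc(F)cc21` gives in a functional assay on MDA-MB-435 cells (Homo sapiens) for inhibition (on this read-out higher numbers stand for weaker inhibition and lower numbers for stronger inhibition), only a limit, > 30000 nM.
Compound 2 `CN[C@H](C#Cc1c(F)ccc2c1/C(=C/c1[nH]ccc1OC)C(=O)N2)CO` gives in this assay 349 nM.
Compound 3 `COc1cc[nH]c1/C=C1\C(=O)Nc2ccc(F)c(C#CC3(O)CCOCC3)c21` gives in this assay 600 nM.

Compound 2 holds the lower of the two numbers in this assay, and its nearest neighbour is compound 3, with a 1.7-fold higher number from compound 2 to compound 3 (0.24 log units; within the scatter), so the two cannot be told apart. Among the measured compounds shown here, compound 1 sits at the limit of > 30000 nM in this assay, at which 1 of the 3 values shown sits, and is the only compound without a group on the triple-bonded carbon.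

Compound 4 `COc1cc[nH]c1/C=C1\C(=O)Nc2ccc(F)c(C#C[C@@H]3C[C@H](O)CN3)c21` is the unmeasured partner of compound 2. 4-hydroxypyrrolidin-2-yl in place of 2-hydroxy-1-(methylamino)ethyl on a triple-bonded carbon

For the measured compounds named here, the only measured step that touches this position is the one from compound 2 to compound 3, where the 2-hydroxy-1-(methylamino)ethyl group was exchanged for a 4-hydroxyoxan-4-yl group and the number stayed within the scatter. The change to compound 4 keeps a hydroxyl and an amine on a small saturated fragment at the same place, so no step beyond the scatter in this assay is expected in either direction; the estimate for the step is a 1.1-fold higher number from compound 2 to compound 4 (0.06 log units; within the scatter).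

For compound 4 in this assay the expected value is 400 nM, with a range from 150 nM to 1100 nM.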

Compound 4, half-maximal inhibitory concentration: 110 nM
Compound 4: the middle estimate sits 3.6-fold (0.56 log units) above what was measured; measured number below the stated range.
By their numbers in this assay, from the lowest: compound 4; then compounds 2 and 3 (each within the scatter of the next). At a limit, above all of these: compound 1.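

On this assay the substituent on the triple-bonded carbon now proves able to move the number beyond the scatter, which the earlier step between the open 2-hydroxy-1-(methylamino)ethyl group and the 4-hydroxyoxan-4-yl group had not shown: 4-hydroxypyrrolidin-2-yl gives a clear gain over the open chain (a 3.2-fold lower number from compound 2 to compound 4 (0.50 log units; beyond the scatter)) and over the oxygen-containing ring (a 5.5-fold lower number from compound 3 to compound 4 (0.74 log units; beyond the scatter)). A ring alone does not account for this gain, since compound 3 also carries a ring and stays within the scatter of compound 2, and a nitrogen alone does not account for it either, since compound 2 has one; among these compounds, only compound 4 carries a ring holding a nitrogen, and it alone stands apart. Nothing in the data shown explains why this group gives the lower number.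

The compounds shown leave open whether the hydroxyl on the ring contributes, which a plain pyrrolidin-2-yl group would test, and whether the defined stereocentres of 4-hydroxypyrrolidin-2-yl matter, which its other stereoisomers would test. They also leave open whether a larger nitrogen ring, such as piperidin-2-yl, would hold the same number.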